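The compounds below may be only part of what the source reports. "The series", "measured", "known", "first", "only" and "open" are said of these compounds alone.

- compound 1 `O=C(/C(=C\c1c(O)cc(O)cc1O)S(=O)(=O)c1ccccc1Br)c1ccc(Cl)cc1` gives 50000 nM
- compound 2 `O=C(/C(=C\c1c(O)cc(O)cc1O)Sc1ccccc1Br)c1ccc(Cl)cc1` gives > 100000 nM as a limit

Both results come from a functional assay on DU-145 cells (Homo sapiens) for inhibition, read by trypan blue exclusion, with a stated time of 96 h (on this read-out higher numbers stand for weaker inhibition of growth and lower numbers for stronger inhibition of growth), and show how much compound is needed to hold back the growth of these cells. For compound 2 there is only a limit, > 100000 nM, and no exact number.

Compound 3 `O=C(/C(=C\c1c(O)cc(O)cc1O)S(=O)(=O)c1ccc(Br)cc1)c1ccc(Cl)cc1` has not yet been measured. The change is (4-bromophenyl)sulfonyl in place of (2-bromophenyl)sulfanyl on a double-bonded chain carbon bound to a carbonyl carbon and a double-bonded chain carbon, in words (4-bromophenyl)sulfonyl in place of (2-bromophenyl)sulfanyl on a double-bonded chain carbon bound to a carbonyl carbon and a double-bonded chain carbon.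

Among the compounds with values here, one measured step bears on this: an at least 2.0-fold higher number from compound 1 to compound 2 (0.30 log units; that floor lies within the scatter). That step went from sulfonyl to sulfanyl, the reverse of the change here, and its size is known only as a floor. Compound 1, which carries the sulfonyl group, gives 50000 nM in this assay. Within the data shown here, no measured step covers the swap from 2-bromophenyl to 4-bromophenyl.

A modest shift toward stronger inhibition of growth is therefore expected, with an estimated at least 3.3-fold lower number from compound 2 to compound 3 (0.52 log units; beyond the scatter) as the result. Compound 3 is expected near 30000 nM, with an estimated range from 6000 nM to 100000 nM.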

Compound 3, concentration for 50% growth inhibition: > 100000 nM
Compound 3 was reported as a limit; the forecaster's own chance of this, stated with the estimate: 20%; middle value at least 3.3-fold (0.52 log units) away from the limit.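

In this assay, within the data shown here, moving from 2-bromophenyl to 4-bromophenyl on the sulfonyl sulfur, a swap no earlier pair covered, gives an at least 2.0-fold higher number from compound 1 to compound 3 (0.30 log units; that floor lies within the scatter); only a floor is known for this step, so it cannot be called a real loss of growth inhibition. The sulfonyl group at this place is also not enough on its own to give an exact number, since compound 3 carries it and still yields only a limit, while compound 1 is the one compound shown with an exact value. Compound 2 and compound 3 both end at a limit, so the step between them cannot be read, and the comparison stops at the same point for both: the limit of > 100000 nM in this assay, at which 2 of the 3 values shown sit.

As far as these compounds go, how far compound 3 truly lies from compound 1 stays open, with only a floor known for that step. Also open, from the compounds shown here alone, is whether an amine or a carboxylic acid in place of the bromine on the phenyl ring of the sulfonyl group would give an exact number in this assay.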